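From Bromophenyl to Thiophenyl on a Shared Core

The source may hold more compounds than are shown below. What is called first, only, known or untested is meant among the compounds shown, and "the series" means these compounds.

Three compounds on one core were tested in a functional assay on 1A9 cells (Homo sapiens) for cytotoxicity; a lower number here means that less compound is needed, a higher number that more compound is needed for the effect. Compound 1 `COC1=C(C)C(=O)/C(=C(O)/C=C/c2ccc(Br)cc2)C(=O)C1(C)C` gives 1.1 ug/mL, the lowest of the three numbers. Compound 2 `COC1=C(C)C(=O)/C(=C(O)/C=C/c2cccc(OC)c2)C(=O)C1(C)C` gives 2.9 ug/mL, and compound 3 `CCc1ccc(/C=C/C(O)=C2/C(=O)C(C)=C(OC)C(C)(C)C2=O)cc1` gives 5.3 ug/mL. The step of a 2.6-fold higher number from compound 1 to compound 2 (0.42 log units; beyond the scatter) and the step of a 4.8-fold higher number from compound 1 to compound 3 (0.68 log units; beyond the scatter) both lie beyond the scatter, whereas the step of a 1.8-fold higher number from compound 2 to compound 3 (0.26 log units; within the scatter) does not.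

The unmeasured compound 4 `COC1=C(C)C(=O)/C(=C(O)/C=C/c2cccs2)C(=O)C1(C)C` differs from compound 1 in one place: thiophen-2-yl in place of 4-bromophenyl on a double-bonded chain carbon bound to a double-bonded chain carbon. Going by the values given here, no measured step exchanges the whole aryl group for a five-membered ring with a hetero atom, so the nearest guides are the two departures from compound 1, namely a 2.6-fold higher number from compound 1 to compound 2 (0.42 log units; beyond the scatter) and a 4.8-fold higher number from compound 1 to compound 3 (0.68 log units; beyond the scatter), each of which raised the number modestly. Among the compounds with values here, on that basis a modest rise in this assay is expected rather than none, though the direction is only weakly supported, since no pair among the three measured compounds tests the same kind of change.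

Compound 4 is therefore expected to show 2.5 ug/mL in this assay, with a range from 1 ug/mL to 6 ug/mL. The step of a 2.3-fold higher number from compound 1 to compound 4 (0.36 log units; beyond the scatter) is the estimated outcome.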

Compound 4, concentration for half-maximal effect: 4 ug/mL
Beside the measured number, compound 4's estimate is 1.6-fold (0.20 log units) below it, and the stated range covers the measured number.
By their numbers in this assay, from the lowest: compound 1; then compounds 2, 4 and 3 (each within the scatter of the next).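

In this assay, thiophen-2-yl on a double-bonded chain carbon bound to a double-bonded chain carbon gives a 3.6-fold higher number from compound 1 to compound 4 (0.56 log units; beyond the scatter), so this five-membered aromatic ring with one hetero atom joins 3-methoxyphenyl and 4-ethylphenyl in standing apart from 4-bromophenyl. Against those two groups the thiophen-2-yl change makes no difference that can be read, since a 1.3-fold lower number from compound 3 to compound 4 (0.12 log units; within the scatter) and a 1.4-fold higher number from compound 2 to compound 4 (0.14 log units; within the scatter) both stay within the scatter, which shows that a smaller ring carrying sulfur in place of a substituted six-membered ring does not separate from them at this position, and that compound 1 alone stands apart among the four. Nothing measured alongside these numbers accounts for the lower number of compound 1.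

What the compounds shown leave open is whether the lower number of compound 1 belongs to bromine in particular or would also appear with 4-chlorophenyl or 4-iodophenyl. They also leave open how this position would respond to a ring carrying nitrogen, such as pyridin-3-yl, or to a phenyl ring bearing an amine or a carboxylic acid.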